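Adding a third methoxy to an allyl-triazole acetamide

The source may report more compounds than this note shows. Statements on the series, on what has been measured and on what is new or still open speak of the compounds shown alone.

Measured compounds:
- compound 1, `C=CCn1c(SCC(=O)Nc2ccc(C(C)=O)cc2)nnc1-c1ccc(OC)c(OC)c1`: 57%
- compound 2, `C=CCn1c(SCC(=O)Nc2ccc(C(C)=O)cc2)nnc1-c1ccc(OC)cc1`: 51%

The two measured compounds share one core and differ only on the aromatic ring that carries the methoxy groups. In a functional assay on the whole organism (strain albino) for inhibition, with Rattus norvegicus as the target, read by paw edema, with stated times of 30 min and 2 h, at a dose of 0.28 mmol/kg by the oral route (on this read-out lower numbers stand for less inhibition and higher numbers for more inhibition at the one dose given (going by the name of the read-out)), compound 1 gives 57%, the higher of the two numbers, and compound 2 gives 51%. Going by the values given here, the only measured step, hydrogen in place of methoxy on an aromatic carbon, is a number 6 percentage points lower from compound 1 to compound 2 (within the scatter), so the two values cannot be told apart.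

Compound 3, `C=CCn1c(SCC(=O)Nc2ccc(C(C)=O)cc2)nnc1-c1cc(OC)c(OC)c(OC)c1`, is not yet measured. It differs from compound 1 by methoxy in place of hydrogen on an aromatic carbon, a methoxy in place of hydrogen on an aromatic carbon, on the same ring where the measured step took a methoxy away. That step, a number 6 percentage points lower from compound 1 to compound 2 (within the scatter), is the one that bears on the change, and it stayed within the scatter; the reverse move, adding a methoxy, is therefore expected to give no step beyond the scatter in this assay either.

For compound 3 the expected step is a number 1 percentage points higher from compound 1 to compound 3 (within the scatter), and its estimated value is 58%, with a range from 44% to 72%.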

Compound 3, a percentage reported as inhibition, in the whole organism at one dose (the size of the read-out at that dose, not a potency): 54%
The estimate for compound 3 lay 4 percentage points above the measured number, within the range that was stated.
By their numbers in this assay, from the lowest: compounds 2, 3 and 1 (each within the scatter of the next).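

In this assay the step from two methoxy groups to three is a number 3 percentage points lower from compound 1 to compound 3 (within the scatter) and so leaves compound 3 indistinguishable from compound 1, with the added methoxy on an aromatic carbon ortho to a methoxy group and meta to a large group. The earlier pair had shown only the loss of a methoxy from this ring, whereas compound 3 shows that a gain of one also stays within the scatter, so neither single change on the ring has yet moved the number beyond it. Nothing in the data offers an explanation for this result.

All the compounds shown carry only methoxy groups or hydrogen on this ring, so it remains open whether a hydroxy group, a chlorine atom or an amine on the same aromatic carbon would give a step beyond the scatter. On these data alone, it is equally open how this assay would respond if the allyl group gave way to a longer chain or the acetyl group to a carboxylic acid.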